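Ether side chain in place of the 1-ethylpentylamino group

This account rests on a few compounds, and the source may have more. Where it says the series, first, only, none or still open, it means among the compounds named here.

Compound 2 `CCCCC(CC)Nc1nc(C)nc2c1nnn2-c1ccc(C(C)C)cc1Br` gives in an in vitro assay on 293-EBNA cells for binding affinity to corticotropin-releasing factor receptor 1 (Homo sapiens) (on this read-out lower numbers stand for stronger inhibition and higher numbers for weaker inhibition), 3.1 nM, the lowest of the two numbers in hand; compound 1 `CCCC(CN(C)C)Nc1nc(C)nc2c1nnn2-c1ccc(C(C)C)cc1Br` gives 38.7 nM. For the measured compounds named here, the single measured step, a 12-fold lower number from compound 1 to compound 2 (1.10 log units; beyond the scatter), changes one side chain for another on a nitrogen on an aromatic ring. Compound 3 `CCOCC(COCC)Oc1nc(C)nc2c1nnn2-c1ccc(C(C)C)cc1Br` brings (a group of 10 heavy atoms (7 carbon, 3 oxygen; no ring) in place of a group of 8 heavy atoms (7 carbon, 1 nitrogen; no ring), on an aromatic carbon). Going by the values given here, no measured step exchanges the amino link for an ether link or removes the hydrogen-bond donor, so the one step bears on this only loosely. A weakening step is expected, a 4.8-fold higher number from compound 2 to compound 3 (0.68 log units; beyond the scatter). Compound 3 is estimated at 15 nM, within 3 nM to 80 nM.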

Compound 3, inhibition constant: 39.7 nM
Compound 3: middle estimate off by 2.6-fold (0.42 log units), on the low side; measured number inside the range.
By their numbers in this assay, from the lowest: compound 2; then compounds 1 and 3 (each within the scatter of the next).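

In this assay, exchanging the (1-ethylpentyl)amino group on this aromatic carbon for the ether side chain, with 0 hydrogen-bond donors, gives a large loss (a 13-fold higher number from compound 2 to compound 3 (1.11 log units; beyond the scatter)), so this position does not tolerate every side chain equally. The side chains of compound 1 and compound 3 read alike (a 1.0-fold higher number from compound 1 to compound 3 (0.01 log units; within the scatter)), although one carries dimethylamino and the other two ethoxymethyl arms. Nothing available explains these results.

Link and chain changed together here, so their contributions remain unseparated. An ether carrying the 1-ethylpentyl chain, or an amine carrying the two ethoxymethyl arms, would separate them.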